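Moving the Nitro Group on a Methylated Analogue

The compounds below may be only part of what the source reports. "The series", "measured", "known", "first", "only" and "open" are said of these compounds alone.

Compound 1 `COc1cc(C(=O)c2cn(-c3ccccc3)cc2-c2cccc([N+](=O)[O-])c2)cc(OC)c1OC` gives 50 nM in a functional assay on MCF7 cells (Homo sapiens) for cytotoxicity, read by MTT assay, with a stated time of 96 h; on this read-out lower numbers stand for stronger inhibition and higher numbers for weaker inhibition. Compound 2 `COc1cc(C(=O)c2cn(-c3ccccc3)cc2-c2ccc([N+](=O)[O-])cc2)cc(OC)c1OC` differs from it by 4-nitrophenyl in place of 3-nitrophenyl on an aromatic carbon and gives 590 nM, a change of a 12-fold higher number from compound 1 to compound 2 (1.07 log units; beyond the scatter). Compound 3 `COc1cc(C(=O)c2cn(-c3cccc(C)c3)cc2-c2cccc([N+](=O)[O-])c2)cc(OC)c1OC` has a different core, the difference being (methyl in place of hydrogen on an aromatic carbon), and gives 880 nM in this assay, a change of an 18-fold higher number from compound 1 to compound 3 (1.25 log units; beyond the scatter). Compound 4 `COc1cc(C(=O)c2cn(-c3cccc(C)c3)cc2-c2ccc([N+](=O)[O-])cc2)cc(OC)c1OC` is not yet measured; it differs from compound 3 by 4-nitrophenyl in place of 3-nitrophenyl on an aromatic carbon, the same kind of change as that between compound 1 and compound 2, though here the place is two ring bonds from the ring atom that bears a 3-methylphenyl group rather than a phenyl group. Because a 12-fold higher number from compound 1 to compound 2 (1.07 log units; beyond the scatter) was large, the expected step is a 6.8-fold higher number from compound 3 to compound 4 (0.83 log units; beyond the scatter), kept a little smaller since compound 3 already gives 880 nM. Compound 4 is estimated at 6000 nM in this assay, with a range from 1500 nM to 25000 nM.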

Compound 4, half-maximal inhibitory concentration: 780 nM
Compound 4: the middle estimate sits 7.7-fold (0.89 log units) above what was measured, outside the stated range (below it).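

In this assay, placing 4-nitrophenyl in place of 3-nitrophenyl gave a 1.1-fold lower number from compound 3 to compound 4 (0.05 log units; within the scatter), so the change seen on the core of compound 1 did not carry over to the core bearing a 3-methylphenyl group: the same change on two cores in this assay, a 12-fold higher number (1.07 log units; beyond the scatter) from compound 1 to compound 2 and a 1.1-fold lower number (0.05 log units; within the scatter) from compound 3 to compound 4, 13-fold (1.12 log units) apart, beyond the scatter of two such steps The methyl change likewise depended on its partner, with a 1.3-fold higher number from compound 2 to compound 4 (0.12 log units; within the scatter) set against the earlier step: the same change on two cores in this assay, an 18-fold higher number (1.25 log units; beyond the scatter) from compound 1 to compound 3 and a 1.3-fold higher number (0.12 log units; within the scatter) from compound 2 to compound 4, 13-fold (1.12 log units) apart, beyond the scatter of two such steps The two changes are therefore not independent across these four compounds, but one pair on each core does not show why, nor how either change would behave on any other core.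

The compounds shown leave open whether an ethyl group or a chlorine atom in place of that methyl would also remove the gap between the two nitro isomers. They also leave open whether an amine in place of the nitro group would follow the pattern of compound 1 and compound 2 or that of compound 3 and compound 4.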